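Methyl in place of carbamoyl on the shared core

This account rests on a few compounds, and the source may have more. Where it says the series, first, only, none or still open, it means among the compounds named here.

- Compound 1 `COc1ccc(/C=C2\c3cc(OC)c(OC)c(OC)c3CC[C@@H]2O)cc1O`: 260 nM
- Compound 2 `COc1ccc(/C=C2\c3cc(OC)c(OC)c(OC)c3CC[C@@H]2O)cc1C(N)=O`: 550 nM

Both values come from a functional assay on HT-29 cells (Homo sapiens) for inhibition, read by MTT assay (on this read-out lower numbers stand for stronger inhibition and higher numbers for weaker inhibition), where compound 2 has the higher of the two numbers. Compound 3 `COc1ccc(/C=C2\c3cc(OC)c(OC)c(OC)c3CC[C@@H]2O)cc1C` follows from compound 2 with methyl in place of carbamoyl on an aromatic carbon. Among the measured compounds shown here, the only measured step at this carbon is modest: a 2.1-fold higher number from compound 1 to compound 2 (0.33 log units; beyond the scatter). For the measured compounds named here, no methyl analogue has been measured, so a return of similar size towards a lower number in this assay is expected, with wide uncertainty. The expected change is a 2.1-fold lower number from compound 2 to compound 3 (0.33 log units; beyond the scatter). The estimate for compound 3 is 260 nM, within 90 nM to 750 nM.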

Compound 3, half-maximal inhibitory concentration: 2560 nM
Compound 3: the middle estimate sits 9.8-fold (0.99 log units) below what was measured; measured number outside the range, above it.
By their numbers in this assay, from the lowest: compound 1; then compound 2; then compound 3.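

Methyl at this aromatic carbon costs more than carbamoyl does: the change gives (a 4.7-fold higher number from compound 2 to compound 3 (0.67 log units; beyond the scatter)), and replacing hydroxy with methyl gives (a 9.8-fold higher number from compound 1 to compound 3 (0.99 log units; beyond the scatter)). The order by number is therefore hydroxy, then carbamoyl, then methyl, so the hydroxy-to-carbamoyl step did not carry over to this change. No supporting data bear on why the number rises.

Open, going by these compounds, is whether an amine or a carboxylic acid at this carbon would stay near compound 1 and compound 2. Also open, on these data alone, is whether a longer chain would rise beyond compound 3.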